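Cap exchange: cyclohexylmethyl to 3-chlorophenoxy

The source may hold more compounds than are shown below. What is called first, only, known or untested is meant among the compounds shown, and "the series" means these compounds.

Compound 2 `CC(C)C[C@H](N)c1cc(C(F)(F)F)ccc1N1CCN(C(=O)CCC2CCCCC2)CC1` gives 5700 nM in an assay on HEK293 cells for displacement of a labelled ligand from Melanocortin receptor 4 (Homo sapiens); a lower number here means a stronger inhibitor, a higher number a weaker inhibitor; compound 1 `COc1ccc(OCC(=O)N2CCN(c3ccc(C(F)(F)F)cc3[C@@H](N)CC(C)C)CC2)cc1` gives 3800 nM, and the gap between the two lies within the scatter, so compound 2 stands nowhere apart. Compound 3 `CC(C)C[C@H](N)c1cc(C(F)(F)F)ccc1N1CCN(C(=O)COc2cccc(Cl)c2)CC1` differs from compound 2 by 3-chlorophenoxy in place of cyclohexylmethyl on a saturated chain carbon bound to a carbonyl carbon. Going by the values given here, the one step that bears on this is a 1.5-fold higher number from compound 1 to compound 2 (0.18 log units; within the scatter), which swapped a phenoxy cap for cyclohexylmethyl and stayed within the scatter. Returning to a phenoxy cap is therefore expected to give a 1.4-fold lower number from compound 2 to compound 3 (0.15 log units; within the scatter), nothing beyond the scatter. Compound 3 is estimated at 4000 nM, range 1500 nM to 11000 nM.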

Compound 3, inhibition constant: 2600 nM
Compound 3: middle estimate off by 1.5-fold (0.19 log units), on the high side, and the stated range covers the measured number.
By their numbers in this assay, from the lowest: compounds 3, 1 and 2 (each within the scatter of the next, the first and the last beyond it).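

In this assay, going by these compounds alone, the change to 3-chlorophenoxy is the first at this position to pass beyond the scatter, though only modestly (a 2.2-fold lower number from compound 2 to compound 3 (0.34 log units; beyond the scatter)). Among the aryloxy caps, 3-chlorophenyl in place of 4-methoxyphenyl on the oxygen leaves the two compounds unresolved (a 1.5-fold lower number from compound 1 to compound 3 (0.16 log units; within the scatter)). No measured evidence bears on why this cap differs from cyclohexylmethyl.

From the compounds shown here alone, since the exchange alters both the ring and the oxygen, which of the two carries the step stays open. So does what an amine or a carboxylic acid would give on this saturated chain carbon.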